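Taking the Trifluoromethyl Off an Inactive Sulfonamide

A few compounds are considered here, and "the series" means these few. Any claim that something is new, unique, unknown or untested is made for them only; others in the source may bear on it.

Compound 1, `O=S(=O)(Nc1ccc(-c2nc3ccccc3o2)cc1)c1ccc(F)c(C(F)(F)F)c1`, was tested in an assay on isolated protein for inhibition of malate dehydrogenase, mitochondrial (Sus scrofa), with stated times of 45 min and 30 min; on this read-out lower numbers stand for stronger inhibition and higher numbers for weaker inhibition. In this assay compound 1 gives > 63000 nM, which is a limit of the assay rather than a measured number. Compound 2, `O=S(=O)(Nc1ccc2oc(-c3ccccc3)nc2c1)c1cccs1`, also gives in this assay > 63000 nM, again a limit. Both results sit at the limit of > 63000 nM in this assay, at which 2 of the 2 values shown sit, so compound 1 stands level with the only other compound shown, and neither shows measurable inhibition.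

Compound 3, `O=S(=O)(Nc1ccc(-c2nc3ccccc3o2)cc1)c1ccc(F)cc1`, is compound 1 with a single change: hydrogen in place of trifluoromethyl on an aromatic carbon. Among the measured compounds shown here, no measured pair differs in only this way, so the size of the step cannot be read from the data. Because compound 1 gives only > 63000 nM, there is nothing pointing toward stronger inhibition for compound 3. The expected step is a step that the limit leaves unreadable from compound 1 to compound 3, meaning none beyond the usual scatter. Compound 3 is therefore estimated at 80000 nM, within a range from 30000 nM to 300000 nM, and most likely again reported only as a limit.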

Compound 3, half-maximal inhibitory concentration: > 63000 nM
Compound 3: only a limit was reported; the forecaster's own chance of this, stated with the estimate: 85%; the middle value does not contradict the limit.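

Compound 1 and compound 3 each give only a limit in this assay, not a measured number, so no step between them can be read: the limit of > 63000 nM in this assay, at which 3 of the 3 values shown sit.

The compounds shown leave open whether hydrogen in place of trifluoromethyl changes inhibition at all, and whether any close relative gives a measurable value.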